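Swapping trifluoromethyl for fluoro in a growth inhibitor

This account rests on a few compounds, and the source may have more. Where it says the series, first, only, none or still open, it means among the compounds named here.

Compound 1 `Cc1cc(-c2nc3cc(F)c(F)cc3s2)ccc1N`: (< 10 nM), a limit of the assay
Compound 2 `Nc1ccc(-c2nc3ccccc3s2)cc1C(F)(F)F`: (5400 nM)

Both compounds were tested in a functional assay on T47D cells (Breast, Homo sapiens) for inhibition; on this read-out lower numbers stand for stronger inhibition of growth and higher numbers for weaker inhibition of growth. Compound 1 is reported only as a limit, (< 10 nM), and not as an exact number. For the measured compounds named here, compound 2 gives 5400 nM, the only exact number so far. On these two values, compound 2 is much the weaker inhibitor of growth, although the two compounds differ in more than one place.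

Compound 3 `Nc1ccc(-c2nc3ccccc3s2)cc1F` keeps all of compound 2 except for one group. It has fluoro in place of trifluoromethyl on an aromatic carbon, ortho to an amino group (fluoro in place of trifluoromethyl on an aromatic carbon). Going by the values given here, no measured pair isolates this exchange, so its size remains a judgement. Compound 2 stands at 5400 nM, which leaves much room for the number to fall. A large fall, meaning stronger inhibition, is therefore expected. The estimated change is a 54-fold lower number from compound 2 to compound 3 (1.73 log units; beyond the scatter), though with wide uncertainty. The estimated value for compound 3 is 100 nM in this assay (expected range 8 nM to 2000 nM).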

Compound 3, concentration for 50% growth inhibition: < 10 nM
Compound 3: a limit, no number (the forecaster's own chance of this, stated with the estimate: 25%); middle value at least 10-fold (1.00 log units) from the limit.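

Compound 1 and compound 2 differ in more than one place, so they could not show whether the group on this aromatic carbon, ortho to an amino group, matters on its own. In this assay, exchanging trifluoromethyl for fluoro at this one position, with the rest of the molecule unchanged, gives an at least 540-fold lower number from compound 2 to compound 3 (2.73 log units; beyond the scatter), so this single change is enough to separate a weak inhibitor of growth from a strong one. The true size of the step stays unknown, and the figure is only a minimum, since compound 3 is reported as a limit and not as an exact number: the limit of < 10 nM in this assay, at which 2 of the 3 values shown sit.

For the compounds shown here, with only two groups compared at this position on the same core, it remains open how chloro, methoxy or an amine on this aromatic carbon would behave, and whether any of them would match fluoro. Compound 1 and compound 3 cannot be ranked against each other either, as both are limits and they differ in more than one place, so the part played by the methyl group of compound 1 stays unresolved.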